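A few compounds are considered here, and "the series" means these few. Any claim that something is new, unique, unknown or untested is made for them only; others in the source may bear on it.

All three measured compounds share one core and differ only in the group on an aromatic nitrogen. Compound 1 `COc1ccc(-c2cc(=O)c3c(OC)cc(OC)cc3n2C)cc1` carries a methyl there, and in a functional assay on KOPN-8 cells (Homo sapiens) for antiproliferative activity, with a stated time of 72 h (a higher number here means that more compound is needed for the effect, a lower number that less compound is needed), compound 1 gives 30000 nM. Compound 2 `C=CCNC(=O)n1c(-c2ccc(OC)cc2)cc(=O)c2c(OC)cc(OC)cc21` carries an allylcarbamoyl instead; in this assay compound 2 gives 12000 nM, a change of a 2.5-fold lower number from compound 1 to compound 2 (0.40 log units; beyond the scatter). Compound 3 `COc1ccc(-c2cc(=O)c3c(OC)cc(OC)cc3n2S(=O)(=O)c2ccc(C#N)cc2)cc1` carries a (4-cyanophenyl)sulfonyl on that nitrogen. In this assay compound 3 reaches only a limit of the assay, > 17200 nM. Among the measured compounds shown here, compound 3 is the one value sitting at the limit of > 17200 nM in this assay, at which 1 of the 3 values shown sits. This leaves a step that the limit leaves unreadable from compound 1 to compound 3 and an at least 1.4-fold higher number from compound 2 to compound 3 (0.15 log units; that floor lies within the scatter). Compound 4 `COc1ccc(-c2cc(=O)c3c(OC)cc(OC)cc3n2S(=O)(=O)c2cccc(Br)c2)cc1` differs from compound 3 in one place: 3-bromophenyl in place of 4-cyanophenyl on a sulfonyl sulfur. For the measured compounds named here, no measured step changes the group on the sulfonyl sulfur, so no direct precedent exists, and the step from compound 3 to compound 4 can be read only against the weak potency of compound 3 in this assay. A number close to that of compound 3 is expected, a step that the limit leaves unreadable from compound 3 to compound 4, with a real chance that only a limit is reported again. Compound 4 is therefore estimated at 20000 nM in this assay, within 7000 nM to 60000 nM.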

Compound 4, half-maximal effective concentration: > 58600 nM
Compound 4 gave a limit, no number; the forecaster's own chance of this, stated with the estimate: 45%; at least 2.9-fold (0.46 log units) between middle value and limit.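

Compound 4 also stops at a limit of the assay in this assay, so a second sulfonyl group on the aromatic nitrogen gives no number: the limit of > 58600 nM in this assay, at which 1 of the 4 values shown sits.

With compound 3 also at a limit, neither the swap on the sulfonyl sulfur nor the step from the methyl to the (4-cyanophenyl)sulfonyl can be read. Two other steps can: against allylcarbamoyl, the new sulfonyl group gives an at least 4.8-fold higher number from compound 2 to compound 4 (0.68 log units; beyond the scatter), a gap that clears the scatter, while against methyl it gives an at least 1.9-fold higher number from compound 1 to compound 4 (0.29 log units; that floor lies within the scatter), so it cannot be told apart from methyl.

From the compounds shown here alone, how 3-bromophenyl and 4-cyanophenyl truly rank stays open. Also open, going by these compounds, is whether an amine or a carboxylic acid on the phenyl ring of the sulfonyl, or a longer chain in place of allyl on the carbamoyl, would bring the number down.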